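Compound 2 to compound 4: a swapped aromatic group

The compounds below may be only part of what the source reports. "The series", "measured", "known", "first", "only" and "open" are said of these compounds alone.

Readings so far in a functional assay on CWR22R cells (Homo sapiens) for antiproliferative activity, read by CCK-8 assay, with a stated time of 6 days; a higher number here means a weaker inhibitor, a lower number a stronger inhibitor

- compound 1 `N#Cc1ccc(N2CCc3cc(-c4cnc5ccccc5c4)ccc32)cc1C(F)(F)F` gives "not determined" (no result reported)
- compound 2 `CCN(c1ccc(C#N)c(Cl)c1)c1cc(-c2cncnc2)ccc1C` gives > 30000 nM
- compound 3 `CCN(c1cccc(-n2ccnc2)c1)c1ccc(C#N)c(C(F)(F)F)c1` gives 19000 nM

The entry for compound 2 is a limit of the assay and not a number (> 30000 nM). Compound 2 therefore has no single value to place in the series (the limit of > 30000 nM in this assay, at which 1 of the 3 values shown sits). Among the measured compounds shown here, compound 3 supplies the only actual number so far (19000 nM). Compound 1 has no result, and no measured step links any of these compounds.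

Compound 4 `CCN(c1ccc(C#N)c(Cl)c1)c1cc(-c2c[nH]nc2C)ccc1C` is still to be measured. It keeps the rest of compound 2 and carries 3-methyl-1H-pyrazol-4-yl in place of pyrimidin-5-yl on an aromatic carbon.

For the measured compounds named here, with no measured step as a guide, only a modest gain in strength is expected in this assay, and another reading at the limit would be no surprise. The expected move is small and uncertain, since it starts from a limit (an at least 2.0-fold lower number from compound 2 to compound 4 (0.30 log units; that floor lies within the scatter)). This expectation leans on compound 3 (19000 nM), which keeps the estimate in the same weak range. The estimated value for compound 4 is 15000 nM with an expected range around it (4000 nM to 30000 nM).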

Compound 4, half-maximal inhibitory concentration: 5380 nM
Compound 4: the middle estimate sits 2.8-fold (0.45 log units) above what was measured; the range from low to high includes it.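

Among the compounds shown here, the aromatic carbon para to a methyl group and meta to a large group responds to the group it carries: in this assay the swap gives an at least 5.5-fold lower number from compound 2 to compound 4 (0.74 log units; beyond the scatter), the first readable step. The two groups match in heavy atoms and in their carbon and nitrogen content, but they differ in type: the six-membered pyrimidin-5-yl has no hydrogen-bond donor, whereas the five-membered 3-methyl-1H-pyrazol-4-yl has one and also carries a methyl group. The step gives only a lower bound on the change because compound 2 carries a limit of the assay and not a number: the limit of > 30000 nM in this assay, at which 1 of the 4 values shown sits.

Going by these compounds, this single swap does not separate the contributions of ring size, the ring hydrogen-bond donor and the methyl group, and the effect of a 1H-pyrazol-4-yl without the methyl, a plain phenyl or an aminomethyl group at this position remains open. Compound 3 differs from compound 4 in more than one place and offers no step, so it also remains open whether this gain would carry over to the other cores shown.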